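Bromine to chlorine on a fused bicyclic amide inhibitor

This account rests on a few compounds, and the source may have more. Where it says the series, first, only, none or still open, it means among the compounds named here.

The compounds measured so far in an assay on isolated protein for inhibition of Ectonucleotide pyrophosphatase/phosphodiesterase family member 1 (Homo sapiens) (on this read-out higher numbers stand for weaker inhibition and lower numbers for stronger inhibition), are:

Compound 1, `COc1ccc(NC(=O)CSc2nc3cnccc3[nH]2)cc1OC`: 44.2 nM
Compound 2, `COc1ccc(NC(=O)CSc2nc3cc(Br)cnc3[nH]2)cc1OC`: 192 nM
Compound 3, `COc1ccc(NC(=O)CSc2nc3c(OC(C)C)nc(N)nc3[nH]2)cc1OC`: 11000 nM

Among these three numbers, compound 2 stands second highest. Its nearest neighbour is compound 1, whose value lies lower by a gap that is beyond the scatter of this assay, so compound 1 is the stronger inhibitor of the pair. Compound 3 sits far above both, its value higher than that of compound 2 by a gap well beyond the scatter. Going by the values given here, no single-point step between measured compounds has been worked out, so nothing more than these values themselves can be read from the set.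

The next compound, compound 4 `COc1ccc(NC(=O)CSc2nc3cc(Cl)cnc3[nH]2)cc1OC`, differs from compound 2 in one place only: chloro in place of bromo on an aromatic carbon. The change is a chloro in place of bromo on an aromatic carbon, and nothing in the measured set shows how such a halogen exchange plays out in this assay. The expectation is therefore a step from compound 2 to compound 4 that stays within the usual scatter, with no direction claimed: a 1.2-fold lower number from compound 2 to compound 4 (0.08 log units; within the scatter). On that basis compound 4 is estimated at 160 nM, in a range from 55 nM to 480 nM.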

Compound 4, inhibition constant: 137 nM
Estimate against measurement, compound 4: 1.2-fold (0.07 log units) above; the range from low to high includes it.
By their numbers in this assay, from the lowest: compound 1; then compounds 4 and 2 (each within the scatter of the next); then compound 3.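

In this assay the exchange of bromo for chloro gives a 1.4-fold lower number from compound 2 to compound 4 (0.15 log units; within the scatter) and the read-out does not separate the two halogens at this position. Going by these compounds alone, this is the only one-place step in the set, and it gives the first direct reading at this aromatic carbon, two atoms from the ring nitrogen, with the rest of the molecule held constant: here a bromine and a chlorine are interchangeable within the scatter of the read-out. The compounds shown offer nothing that would explain this result.

From the compounds shown here alone, that reading covers only these two halogens, so it remains open whether the same carbon would tolerate a fluoro, a methyl, a methoxy, a nitrile or an amine as readily, or whether such a group would move the number beyond the scatter. Going by these compounds, it also remains open whether a plain hydrogen at this place on the core of compound 2 would read any differently from either halogen.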